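Sulfonyl aryl swap on compound 3: cytotoxicity notes

The source may report more compounds than this note shows. Statements on the series, on what has been measured and on what is new or still open speak of the compounds shown alone.

Measured in an ADME assay on HEK-293T cells (Homo sapiens) for cytotoxicity, read by MTT assay, with a stated time of 24 h; on this read-out higher numbers stand for lower toxicity in this test and lower numbers for higher toxicity in this test:
- compound 1 `O=[N+]([O-])c1ccc(S(=O)(=O)n2c(-c3cn(-c4ccccc4)nc3-c3ccc(F)cc3)nc3ccccc32)cc1`: 189000 nM
- compound 2 `COc1ccc(S(=O)(=O)n2c(-c3cn(-c4ccccc4)nc3-c3ccc(C(F)(F)F)cc3)nc3ccccc32)cc1`: > 300000 nM (a limit)
- compound 3 `Cc1ccc(C)c(S(=O)(=O)n2c(-c3cn(-c4ccccc4)nc3-c3ccc(C(F)(F)F)cc3)nc3ccccc32)c1`: 223000 nM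

Not yet measured: compound 4 `O=[N+]([O-])c1ccc(S(=O)(=O)n2c(-c3cn(-c4ccccc4)nc3-c3ccc(C(F)(F)F)cc3)nc3ccccc32)cc1`.

Compound 3 gives 223000 nM and compound 1 gives 189000 nM, two numbers within the scatter of each other. The value of compound 2 is a limit of the assay, and the series has one such value: the limit of > 300000 nM in this assay, at which 1 of the 3 values shown sits.

The change under study is 4-nitrophenyl in place of 2,5-dimethylphenyl on a sulfonyl sulfur.

Within the data shown here, one measured step bears on it, also an exchange of the group on a sulfonyl sulfur: an at least 1.3-fold lower number from compound 2 to compound 3 (0.12 log units; that floor lies within the scatter). That step starts from a limit, and its floor gives no firm size. Among the measured compounds shown here, compound 1 also carries 4-nitrophenyl on a sulfonyl sulfur, and its 189000 nM offers the only direct reading of that group in this assay. For the measured compounds named here, no step with that group has been measured.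

On these grounds, no step beyond the scatter is expected, in either direction: the expected change is a 1.1-fold lower number from compound 3 to compound 4 (0.05 log units; within the scatter). For compound 4 the estimated value is 200000 nM, with an expected range of 110000 nM to 300000 nM.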

Compound 4, half-maximal cytotoxic concentration: 163000 nM
Compound 4: middle estimate off by 1.2-fold (0.09 log units), on the high side; the range from low to high includes it.
By their numbers in this assay, from the lowest: compounds 4, 1 and 3 (each within the scatter of the next). At a limit, above all of these: compound 2.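

In this assay, the exchange on the sulfonyl sulfur now has a direct reading, with the rest of the structure unchanged: a 1.4-fold lower number from compound 3 to compound 4 (0.14 log units; within the scatter). The fluoro and trifluoromethyl groups on the aromatic carbon can also be compared with 4-nitrophenyl held on the sulfonyl sulfur, giving a 1.2-fold lower number from compound 1 to compound 4 (0.06 log units; within the scatter), so neither single change moves the number beyond the scatter. Nitro in place of methoxy on an aromatic carbon gives only a floor, an at least 1.8-fold lower number from compound 2 to compound 4 (0.26 log units; that floor lies within the scatter), and the value of compound 2 is a limit rather than a number: the limit of > 300000 nM in this assay, at which 1 of the 4 values shown sits.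

From the compounds shown here alone, the true distance between compound 2 and the other three compounds remains open, as does the size of any real difference between 4-methoxyphenyl and 4-nitrophenyl on the sulfonyl sulfur. Going by these compounds, it is also open whether a sulfonyl aryl group bearing an amine or a carboxylic acid, or an alkyl group in place of the aryl ring, would shift the number beyond the scatter in this assay.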